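The source may hold more compounds than are shown below. What is called first, only, known or untested is meant among the compounds shown, and "the series" means these compounds.

In a functional assay for inhibition, with Rattus norvegicus as the target (a lower number here means a stronger inhibitor, a higher number a weaker inhibitor), compound 1 `CC(/N=c1\c(O)c(O)\c1=N/c1cccnc1)C(C)(C)C` gives 1950 nM, and compound 3 `CC(/N=c1\c(O)c(O)\c1=N/c1ccc(Br)cc1)C(C)(C)C` gives 1260 nM. These two values lie within the usual scatter of each other, so neither ranks ahead. Compound 2 `CC(/N=c1\c(O)c(O)\c1=N/c1cccnc1O)C(C)(C)C` reads > 30000 nM, which is a limit of the assay and not a number. Against that limit, the comparison is large: an at least 23-fold lower number from compound 2 to compound 3 (1.37 log units; beyond the scatter).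

Compound 4 `CC(/N=c1\c(O)c(O)\c1=N/c1ccc(S(N)(=O)=O)cc1)C(C)(C)C` keeps all of compound 3 except one group, with sulfamoyl in place of bromo on an aromatic carbon, para to a large group: sulfamoyl in place of bromo on an aromatic carbon. Going by the values given here, no measured step makes this exact change, but two give some guidance. Exchanging the whole aromatic group made no clear difference: a 1.5-fold lower number from compound 1 to compound 3 (0.19 log units; within the scatter). Adding a single hydroxy made a large difference: an at least 15-fold higher number from compound 1 to compound 2 (1.18 log units; beyond the scatter). A moderate rise is therefore expected, well short of the hydroxy step, though the evidence for this is thin. The expected change is a 2.0-fold higher number from compound 3 to compound 4 (0.30 log units; within the scatter). For compound 4, the estimated value is 2500 nM, with an expected range of 500 nM to 15000 nM.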

Compound 4, half-maximal inhibitory concentration: > 30000 nM
Compound 4: only a limit was reported (the forecaster's own chance of this, stated with the estimate: 15%); at least 12-fold (1.07 log units) between middle value and limit.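

At this position, para to a large group, the aromatic ring does not accept every substituent: in this assay, sulfamoyl in place of bromo gives an at least 23-fold higher number from compound 3 to compound 4 (1.37 log units; beyond the scatter). Going by these compounds alone, until now, the only change that kept a value close to that of compound 1 was the exchange of the whole aromatic group for the 4-bromophenyl of compound 3, and this result shows that a single substituent on that ring can decide the outcome. The step is only a minimum, so its full size stays unknown: the limit of > 30000 nM in this assay, at which 2 of the 4 values shown sit.

The compounds shown leave open whether the loss belongs to sulfamoyl as a whole or to its nitrogen end, which a methylsulfonyl group in the same place could separate. They also leave open how an amine or a carboxylic acid at this position would read.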